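From 2,4-dichlorophenyl to 4-bromophenyl on the shared core

This account rests on a few compounds, and the source may have more. Where it says the series, first, only, none or still open, it means among the compounds named here.

Compound 1 `C/C(=N\Nc1nc(C)cs1)c1ccc(Cl)c(Cl)c1`, compound 2 `C/C(=N\Nc1nc(-c2ccccn2)cs1)c1ccc(Cl)c(Cl)c1` and compound 3 `C/C(=N\Nc1nc(-c2ccc(Cl)cc2Cl)cs1)c1ccc(Cl)c(Cl)c1` share one core and differ in the group on an aromatic carbon of the five-membered aromatic ring. In an ADME assay on J774 cells (Mus musculus) for cytotoxicity, read by resazurin assay, with a stated time of 72 h (a higher number here means that more compound is tolerated, a lower number that less compound is tolerated), compound 1 gives 33700 nM and compound 2 gives 10100 nM. Compound 3 reads > 50000 nM, which is a limit of the assay and not a number.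

Compound 4 `C/C(=N\Nc1nc(-c2ccc(Br)cc2)cs1)c1ccc(Cl)c(Cl)c1` has 4-bromophenyl in place of 2,4-dichlorophenyl on the same aromatic carbon: 4-bromophenyl in place of 2,4-dichlorophenyl on an aromatic carbon.

Three measured steps at this carbon bear on the change. Pyridin-2-yl in place of methyl gives a 3.3-fold lower number from compound 1 to compound 2 (0.52 log units; beyond the scatter). 2,4-Dichlorophenyl in place of methyl gives an at least 1.4-fold higher number from compound 1 to compound 3 (0.17 log units; that floor lies within the scatter). 2,4-Dichlorophenyl in place of pyridin-2-yl gives an at least 4.9-fold higher number from compound 2 to compound 3 (0.69 log units; beyond the scatter). The last two steps give only floors, and none of the three exchanges one phenyl group for another, so the precedent is indirect. Across these steps the measured numbers stay within a modest span, so a modest move toward a lower number is expected, with a reading at the limit still possible. The expected change is an at least 2.0-fold lower number from compound 3 to compound 4 (0.30 log units; that floor lies within the scatter). For compound 4 the estimated value in this assay is 25000 nM, with an expected range of 9000 nM to 50000 nM.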

Compound 4, half-maximal cytotoxic concentration: > 50000 nM
Compound 4 gave a limit, no number (the forecaster's own chance of this, stated with the estimate: 25%); middle value at least 2.0-fold (0.30 log units) from the limit.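

In this assay, 4-bromophenyl also reaches the limit of the assay at this carbon, next to the ring nitrogen, so a reading at the limit is no longer confined to 2,4-dichlorophenyl among the groups shown. Replacing pyridin-2-yl with 4-bromophenyl gives an at least 4.9-fold higher number from compound 2 to compound 4 (0.69 log units; beyond the scatter), which matches the separation already seen with 2,4-dichlorophenyl, while replacing methyl gives an at least 1.4-fold higher number from compound 1 to compound 4 (0.17 log units; that floor lies within the scatter), so this floor sets no order between those two compounds. The direct exchange of the two phenyl groups cannot be read, because both compounds sit at the limit: the limit of > 50000 nM in this assay, at which 2 of the 4 values shown sit.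

Any difference between compound 3 and compound 4 remains hidden, so the compounds shown do not tell whether the number of chlorine atoms, the bromine or the phenyl ring itself accounts for these readings. Also open, on these data alone, is whether an unsubstituted phenyl, or a phenyl carrying an amine or a carboxylic acid, would stay at the limit. Such a group could instead fall toward compound 2, which gives 10100 nM.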